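Swapping chloro for acetamido on the benzyl ring

A few compounds are considered here, and "the series" means these few. Any claim that something is new, unique, unknown or untested is made for them only; others in the source may bear on it.

Among the measured compounds shown here, compound 3 `Nc1n[nH]c2cc(-c3ccc(=O)n(Cc4cccc(Cl)c4)c3)ccc12` gives 11 nM in an assay for inhibition of MAP kinase-interacting serine/threonine-protein kinase 1 (Homo sapiens), read by luminescence and ADP-Glo, with a stated time of 2 h (a lower number here means a stronger inhibitor, a higher number a weaker inhibitor), the lowest of the three numbers measured so far. For the measured compounds named here, compound 1 `Nc1n[nH]c2cc(-c3ccc(=O)n(Cc4ccccc4F)c3)ccc12` gives 12 nM, and the step of a 1.1-fold lower number from compound 1 to compound 3 (0.04 log units; within the scatter) is the only single-point change available. Going by the values given here, compound 2 `CC(=O)Nc1cccc(Cn2cc(-c3ccc4cn[nH]c4c3)ccc2=O)c1` gives 163 nM and lacks the amino group on the shared core; no single step connects it to compound 3. Compound 4 `CC(=O)Nc1cccc(Cn2cc(-c3ccc4c(N)n[nH]c4c3)ccc2=O)c1` carries acetamido in place of chloro on an aromatic carbon. Compound 4 shares its acetamido benzyl group with compound 2 and its amino-bearing core with compound 3, but the amino group itself has never been varied alone here. The measured step from compound 1 to compound 3 shows that a change of substituent on the benzyl ring did nothing beyond the scatter, while compound 2 sits far above compound 3. Compound 4 is therefore expected to fall between these, estimated at 40 nM with a range of 10 nM to 160 nM, a step of a 3.6-fold higher number from compound 3 to compound 4 (0.56 log units; beyond the scatter) toward a higher number.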

Compound 4, half-maximal inhibitory concentration: 55 nM
The estimate for compound 4 lay 1.4-fold (0.14 log units) below the measured number, and the stated range covers the measured number.
By their numbers in this assay, from the lowest: compounds 3 and 1 (each within the scatter of the next); then compound 4; then compound 2.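

In this assay, this place on the benzyl ring responds to a change of group: acetamido in place of chloro gives a 5.0-fold higher number from compound 3 to compound 4 (0.70 log units; beyond the scatter), whereas the earlier change on the same ring, 3-chlorophenyl in place of 2-fluorophenyl, gave only a 1.1-fold lower number from compound 1 to compound 3 (0.04 log units; within the scatter). With acetamido held constant, the amino group on the shared core can now be read alone, and its addition gives a 3.0-fold lower number from compound 2 to compound 4 (0.47 log units; beyond the scatter). Nothing available accounts for either step.

The compounds shown leave open whether the higher number follows from the acetamido group as a whole or from one part of it, a question that a plain amine or a methoxy group on the same aromatic carbon could address. They also leave open whether the amino group has a step of similar size when chloro stands on the benzyl ring.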